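A fluoro swap in a series without clear steps

The source may hold more compounds than are shown below. What is called first, only, known or untested is meant among the compounds shown, and "the series" means these compounds.

compound 1 `O=C1NC(=O)/C(=C/c2cn(Cc3ccccc3)c3ccccc23)N1`: 15700 nM
compound 2 `O=C1NC(=O)/C(=C/c2cn(Cc3ccc([N+](=O)[O-])cc3)c3ccccc23)N1`: 23300 nM
compound 3 `COC(=O)c1ccc(Cn2cc(/C=C3\NC(=O)NC3=O)c3ccccc32)cc1`: 18400 nM

In a functional assay on MDA-MB-231 cells (Homo sapiens) for antiproliferative activity, read by trypan blue exclusion, with a stated time of 24 h (on this read-out lower numbers stand for stronger inhibition and higher numbers for weaker inhibition), compound 3 gives 18400 nM, a number that cannot be separated from those of the other two compounds. The measured steps to it are a 1.2-fold higher number from compound 1 to compound 3 (0.07 log units; within the scatter) and a 1.3-fold lower number from compound 2 to compound 3 (0.10 log units; within the scatter).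

Compound 4 `O=C1NC(=O)/C(=C/c2cn(Cc3ccc(F)cc3)c3ccccc23)N1` keeps the shared core and changes one group, with fluoro in place of methoxycarbonyl on an aromatic carbon.

The closest evidence comes from swaps on that same aromatic carbon. Besides the two steps above, there is a 1.5-fold higher number from compound 1 to compound 2 (0.17 log units; within the scatter). Hydrogen, nitro and methoxycarbonyl therefore all gave similar numbers, although no fluoro compound has yet been measured. On that evidence, the change should not move the number beyond the scatter. The expected step is a 1.0-fold lower number from compound 3 to compound 4 (0.01 log units; within the scatter).

For compound 4 the estimated value is 18000 nM, with an expected range from 10000 nM to 32000 nM.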

Compound 4, half-maximal inhibitory concentration: 32800 nM
The estimate for compound 4 lay 1.8-fold (0.26 log units) below the measured number, outside the stated range (above it).
By their numbers in this assay, from the lowest: compounds 1, 3, 2 and 4 (each within the scatter of the next, the first and the last beyond it).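

In this assay, among the compounds shown here, fluoro is the only group on this aromatic carbon that gives a step beyond the scatter, though only against hydrogen and only modestly: a 2.1-fold higher number from compound 1 to compound 4 (0.32 log units; beyond the scatter). Against the two larger groups the change stays within the scatter, with a 1.8-fold higher number from compound 3 to compound 4 (0.25 log units; within the scatter) and a 1.4-fold higher number from compound 2 to compound 4 (0.15 log units; within the scatter), so the position is not entirely indifferent to what sits there, yet fluoro separates from hydrogen alone. Nothing available explains this difference.

The compounds shown leave open whether this small separation from hydrogen would hold up in repeated measurements. They also leave open whether another group on the same carbon, such as an amine or a carboxylic acid, could give a number clearly lower than that of compound 1.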